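The compounds below may be only part of what the source reports. "The series", "measured", "known", "first", "only" and "open" are said of these compounds alone.

Working notes on the series. In a functional assay on the whole organism for inhibition, with Mus musculus as the target (on this read-out lower numbers stand for an effect already at smaller amounts and higher numbers for an effect only at larger amounts of compound), compound 1 (`CCCNC(=O)Nc1cccc2c1CN(C)CC2c1ccccc1`) gives > 80 mg/kg and this is a limit of the assay, not a number. Compound 2 (`CCCCNC(=O)Nc1cccc2c1CN(C)CC2c1ccc(C)cc1`) gives about 15 mg/kg in this assay as a measured number.

Compound 3 (`CCOC(=O)Nc1cccc2c1CN(C)CC2c1ccccc1`) has not yet been measured. It carries ethoxy in place of propylamino on a carbonyl carbon and keeps the rest of the core of compound 1. In other words, (propylcarbamoyl)amino gives way to (ethoxycarbonyl)amino.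

Among the measured compounds shown here, no measured step isolates this change, so the size of the step rests on little. For the measured compounds named here, with compound 2 at about 15 mg/kg as the only number so far, a move toward lower numbers is expected for compound 3. A second limit remains a real possibility for compound 3. The estimated change is an at least 2.0-fold lower number from compound 1 to compound 3 (0.30 log units; that floor lies within the scatter) and it is a cautious expectation. In this assay the estimate for compound 3 is 40 mg/kg with an expected range from 12 mg/kg to 130 mg/kg as the likely result.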

Compound 3, dose for half-maximal effect: about 4 mg/kg
Estimate against measurement, compound 3: 10-fold (1.00 log units) above, and the stated range ends above it.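

Ethoxy in place of propylamino on a carbonyl carbon gives an at least 20-fold lower number from compound 1 to compound 3 (1.30 log units; beyond the scatter) in this assay, the first change in the series that can be read in one place, and it shows that this position can carry a large shift on the shared core. The change takes away the hydrogen-bond donor counted on propylamino, brings in the hydrogen-bond acceptor counted on ethoxy and shortens the group, and the pair alone cannot say which of these carries the step. Compound 1 stands at a limit of the assay and not at a number, so the step is a floor and its full size stays unknown because of where that compound sits: the limit of > 80 mg/kg in this assay, at which 1 of the 3 values shown sits.

Open, as far as these compounds go, is whether the step follows the oxygen on the carbonyl carbon or the length of the chain, which methoxy, butoxy or dimethylamino in the same place would help to separate. Compound 2 differs from compound 1 in more than one place, so it gives no separate reading of the propylamino group or of a methyl group on the phenyl ring of compound 3.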